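The compounds below may be only part of what the source reports. "The series", "measured", "known", "first", "only" and "open" are said of these compounds alone.

Compound 1 `CC(C)(C)OC(=O)N1CCC(Oc2cccc3c2ccn3-c2ccc(S(C)(=O)=O)cc2)CC1`; in a functional assay on CHO-K1 cells for agonist activity at Glucose-dependent insulinotropic receptor (Homo sapiens), read by a luciferase reporter, with a stated time of 5 h (a higher number here means that more compound is needed for the effect, a lower number that less compound is needed), compound 1 gives 631 nM.
Compound 2 `CC(C)OC(=O)N1CCC(Oc2ncnc3c2CCN3c2ccc(-c3cccn3C)cc2F)CC1`; in this assay compound 2 gives 158 nM.
Compound 3 `CCCOC(=O)N1CCC(Oc2ncnc3c2CCN3c2ccc(S(C)(=O)=O)cc2F)CC1`; in this assay compound 3 gives 79.4 nM.

Among these three, compound 3 has the lowest number. Its nearest neighbour is compound 2, whose value lies within the scatter of repeated measurements, so the two cannot be told apart; compound 1 lies beyond the scatter, with the higher number of the pair. Compound 4 `CC(C)S(=O)(=O)N1CCC(Oc2ncnc3c2CCN3c2ccc(S(C)(=O)=O)cc2F)CC1` has not yet been measured. It differs from compound 3 in one place: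

isopropylsulfonyl in place of propoxycarbonyl on an amine nitrogen in a ring

Among the measured compounds shown here, no step between measured compounds covers this change, and none of the measured compounds carries a sulfonyl group in that place, so the size of the step cannot be read from the set. The expectation is therefore cautious: compound 4 is expected to give a somewhat higher number than compound 3, with a step of a 1.6-fold higher number from compound 3 to compound 4 (0.21 log units; within the scatter) that may well stay within the scatter. On that basis compound 4 is estimated at 130 nM in this assay, within a range from 35 nM to 500 nM.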

Compound 4, half-maximal effective concentration: 1260 nM
For compound 4 the middle estimate is 9.7-fold (0.99 log units) below the measured one, outside the stated range (above it).
By their numbers in this assay, from the lowest: compounds 3 and 2 (each within the scatter of the next); then compounds 1 and 4 (each within the scatter of the next).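

Swapping propoxycarbonyl for isopropylsulfonyl on the amine nitrogen in a ring gives, in this assay, a 16-fold higher number from compound 3 to compound 4 (1.20 log units; beyond the scatter), which is the first reading of a sulfonyl group in this place and shows that the place is sensitive to this change. The step is large even though the two groups have the same count of heavy atoms and of hydrogen-bond acceptors, and neither has a ring or a net charge, so these counts do not predict the outcome here. Nothing given here identifies what in the change produces the step.

From the compounds shown here alone, it remains open whether the step belongs to the sulfonyl link or to the branched isopropyl chain, and a straight propylsulfonyl on the same core would separate the two. Going by these compounds, how an amide or a urea would read in this place also remains open.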